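Methoxy for hydroxymethyl on a second curcuminoid enaminone

This account rests on a few compounds, and the source may have more. Where it says the series, first, only, none or still open, it means among the compounds named here.

Compound 1 `O=C(/C=C(/C=C/c1ccc(O)cc1)NCCCO)/C=C/c1ccc(O)cc1` gave 128000 nM in a physicochemical assay for solubility, using the shake flask method, in phosphate buffer, with a stated time of 24 h, at pH 6.8; on this read-out lower numbers stand for lower solubility and higher numbers for higher solubility. Compound 2 `COc1cc(/C=C/C(=O)/C=C(/C=C/c2ccc(O)c(OC)c2)NCCCO)ccc1O` gave 56300 nM in this assay. Compound 3 `COCCNC(=C\C(=O)/C=C/c1ccc(O)cc1)/C=C/c1ccc(O)cc1` gave 46100 nM in this assay.

The step from compound 1 to compound 3 is a single change, (methoxy in place of hydroxymethyl on a saturated chain carbon, two bonds along the chain from an amine nitrogen), and it made a 2.8-fold lower number from compound 1 to compound 3 (0.44 log units; beyond the scatter). Compound 2 stands second highest of the three in this assay; next to compound 3 it lies within the scatter, and against compound 1 it lies beyond it. The difference between the core of compound 1 and the core of compound 2 is not broken down here.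

Compound 4 `COCCNC(=C\C(=O)/C=C/c1ccc(O)c(OC)c1)/C=C/c1ccc(O)c(OC)c1` has not yet been measured in this assay. It differs from compound 2 by methoxy in place of hydroxymethyl on a saturated chain carbon, two bonds along the chain from an amine nitrogen, the same change that turned compound 1 into compound 3. Because the earlier step gave a 2.8-fold lower number from compound 1 to compound 3 (0.44 log units; beyond the scatter), a step of similar size is expected here, so that compound 4 is estimated at a 2.8-fold lower number from compound 2 to compound 4 (0.45 log units; beyond the scatter) against compound 2. On that basis compound 4 is expected to give about 20000 nM in this assay, estimated to lie between 8000 nM and 50000 nM.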

Compound 4, solubility: 12700 nM
Beside the measured number, compound 4's estimate is 1.6-fold (0.20 log units) above it; low and high end bracket the measured number.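

In this assay, the swap of (3-hydroxypropyl)amino for (2-methoxyethyl)amino gave a 4.4-fold lower number from compound 2 to compound 4 (0.65 log units; beyond the scatter), which runs the same way as on the other core, where it gave a 2.8-fold lower number from compound 1 to compound 3 (0.44 log units; beyond the scatter). Both steps lie beyond the usual scatter, so in this series the direction of the change held on the two cores shown, but two cores are too few to show that it would hold on a third or to fix a size for the step on any other core. Nothing measured here accounts for the lower numbers on either core.

The compounds shown leave open how much of the step belongs to the methoxy group and how much to the length of the chain, a question that a 3-methoxypropyl or a 2-hydroxyethyl group on the amine could address. They also leave open how a longer chain, or a chain ending in a carboxylic acid or an amine, would read in this assay on either core.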